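Swapping a Hydroxy for an Isopropyl on the Aryl Ring

The source may hold more compounds than are shown below. What is called first, only, known or untested is meant among the compounds shown, and "the series" means these compounds.

Three compounds sharing a phenylpiperazine linked through a three-carbon chain to an amide-bearing pyridine have been tested in a functional assay on aorta for antagonist activity at Alpha-1D adrenergic receptor (Rattus norvegicus); on this read-out lower numbers stand for tighter binding and higher numbers for weaker binding. Compound 1, `COc1ccccc1N1CCN(CCCNc2ncc(C#N)cc2C(=O)N(C)C)CC1`, gives 20 nM. Compound 2, `COc1ccccc1N1CCN(CCCNc2ccncc2C(=O)N(C(C)C)C(C)C)CC1`, gives 251 nM. Compound 3, `CN(C)C(=O)c1cccnc1NCCCN1CCN(c2ccccc2O)CC1`, gives 63.1 nM, which places it second highest of the three numbers: compound 1 sits at a lower number, beyond the scatter, and compound 2 at a higher number, also beyond the scatter. These three differ in more than one place, so no single change can be read off between them.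

The next compound, compound 4, `CC(C)c1ccccc1N1CCN(CCCNc2ncccc2C(=O)N(C)C)CC1`, keeps the core of compound 3 and changes only the group on the phenyl ring: isopropyl in place of hydroxy on an aromatic carbon. A hydrogen-bond donor and acceptor leave and a three-carbon group enters, on an aromatic carbon ortho to a large group. For the measured compounds named here, no measured pair shows this swap, so the expectation rests on compound 3 alone. A modest weakening is expected, estimated as a 1.6-fold higher number from compound 3 to compound 4 (0.20 log units; within the scatter), though the step may stay within the scatter. Compound 4 is therefore expected to give about 100 nM in this assay, in a range from 25 nM to 400 nM.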

Compound 4, dissociation constant: 63.1 nM
For compound 4 the middle estimate is 1.6-fold (0.20 log units) above the measured one, within the range that was stated.
By their numbers in this assay, from the lowest: compound 1; then compounds 3 and 4 (each within the scatter of the next); then compound 2.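

For the compounds shown here, the swap from 2-hydroxyphenyl to 2-isopropylphenyl gives no change at the digits printed from compound 3 to compound 4 (within the scatter) in this assay, and this is the first pair here that differs in one place only, so it is the first direct reading of a change on the phenyl ring. At this position, on an aromatic carbon ortho to a large group, the hydrogen-bond donor and acceptor of hydroxy can leave and the three carbons of isopropyl can enter with no difference beyond the usual scatter, although this rests on a single pair. Nothing available here explains why two such different groups read alike.

The compounds shown leave open whether other groups at this position, such as an amine, a carboxylic acid or a longer alkyl chain, would also match hydroxy and isopropyl in this assay. They also leave open whether the same swap would read alike on the core of compound 1 or the core of compound 2, each of which differs from compound 3 in more than one place.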